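The source may report more compounds than this note shows. Statements on the series, on what has been measured and on what is new or still open speak of the compounds shown alone.

Measured so far in a functional assay on the whole organism with Canis familiaris (Canis lupus familiaris) as the target; on this read-out higher numbers stand for an effect only at larger amounts of compound and lower numbers for an effect already at smaller amounts:
compound 1 `COc1cc(C)ccc1-c1nc2cc[nH]cc-2n1` gives 0.28 mg/kg
compound 2 `COc1cc([N+](=O)[O-])ccc1-c1nc2cc[nH]cc-2n1` gives 0.015 mg/kg
compound 3 `COc1cc(OS(C)(=O)=O)ccc1-c1nc2cc[nH]cc-2n1` gives 0.006 mg/kg

Compound 3 has the lowest number of the three, and its steps to both others lie beyond the scatter. Compound 4 `COc1cc(C(F)(F)F)ccc1-c1nc2cc[nH]cc-2n1` has trifluoromethyl in place of (methylsulfonyl)oxy on an aromatic carbon. Going by the values given here, no measured step involves trifluoromethyl, so the evidence is indirect. Replacing methyl gave large steps (a 19-fold lower number from compound 1 to compound 2 (1.27 log units; beyond the scatter)) and (a 47-fold lower number from compound 1 to compound 3 (1.67 log units; beyond the scatter)), whereas exchanging the two replacements gave a modest one (a 2.5-fold lower number from compound 2 to compound 3 (0.40 log units; beyond the scatter)). Trifluoromethyl is therefore expected to fall nearer these two than methyl, with a modest rise in this assay (a 5.0-fold higher number from compound 3 to compound 4 (0.70 log units; beyond the scatter)). For compound 4 the estimated value is 0.03 mg/kg (range 0.008 mg/kg to 0.12 mg/kg).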

Compound 4, dose for half-maximal effect: 0.009 mg/kg
Compound 4: the middle estimate sits 3.3-fold (0.52 log units) above what was measured; low and high end bracket the measured number.
By their numbers in this assay, from the lowest: compounds 3, 4 and 2 (each within the scatter of the next, the first and the last beyond it); then compound 1.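

In this assay a further replacement of methyl at this position again gives a large step, a 31-fold lower number from compound 1 to compound 4 (1.49 log units; beyond the scatter), while trifluoromethyl sits level with the other two replacements: a 1.5-fold higher number from compound 3 to compound 4 (0.18 log units; within the scatter) and a 1.7-fold lower number from compound 2 to compound 4 (0.22 log units; within the scatter). Trifluoromethyl has no hydrogen-bond acceptors, unlike (methylsulfonyl)oxy, so acceptors in this group are not required for a low number among these compounds. No measurement shown explains these steps. As far as these compounds go, whether an amine, a carboxylic acid or a nitrile here would keep the number this low remains open, as does the effect of trifluoromethyl elsewhere on the ring.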